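This account rests on a few compounds, and the source may have more. Where it says the series, first, only, none or still open, it means among the compounds named here.

Measured in a functional assay on RT-112 cells (Homo sapiens) for antiproliferative activity, read by MTT assay, with a stated time of 72 h; a higher number here means a weaker inhibitor of growth, a lower number a stronger inhibitor of growth:
- compound 1 `COc1cc(Nc2ncnc3c(NC(=O)Nc4ccc(C)c(C)c4)cccc23)cc(OC)c1`: 8.8 nM
- compound 2 `COc1cc(Nc2ncnc3c(NC(=O)Nc4cc(Cl)cc(Cl)c4)cccc23)cc(OC)c1`: 30.2 nM
- compound 3 `COc1cc(Nc2ncnc3c(NC(=O)Nc4cc(C)cc(C)c4)cccc23)cc(OC)c1`: 10100 nM

Compound 3 has the highest number of the three in this assay, at 10100 nM. Compound 4 `CCOC(=O)c1ccc(NC(=O)Nc2cccc3c(Nc4cc(OC)cc(OC)c4)ncnc23)cc1` carries 4-(ethoxycarbonyl)phenyl in place of 3,5-dimethylphenyl on an amide-type nitrogen.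

Three measured steps change the group at this same place. Two are large, a 1100-fold higher number from compound 1 to compound 3 (3.06 log units; beyond the scatter) and a 330-fold higher number from compound 2 to compound 3 (2.52 log units; beyond the scatter), and both end at compound 3. The third, a 3.4-fold higher number from compound 1 to compound 2 (0.54 log units; beyond the scatter), is modest. So both other groups tested here give far lower numbers than 3,5-dimethylphenyl does, though no measured compound carries 4-(ethoxycarbonyl)phenyl. Compound 4 is therefore expected to move away from compound 3 towards lower numbers, probably by a large step but without reaching compound 1 or compound 2 with any certainty. The expected change is a 51-fold lower number from compound 3 to compound 4 (1.70 log units; beyond the scatter). For compound 4 the estimated value is 200 nM. The expected range for compound 4 runs from 15 nM to 5000 nM.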

Compound 4, concentration for 50% growth inhibition: 317 nM
Beside the measured number, compound 4's estimate is 1.6-fold (0.20 log units) below it; the measured number falls inside the stated range.
By their numbers in this assay, from the lowest: compound 1; then compound 2; then compound 4; then compound 3.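

In this assay, 4-(ethoxycarbonyl)phenyl on the amide-type nitrogen gives a 32-fold lower number from compound 3 to compound 4 (1.50 log units; beyond the scatter), so a group bearing an ester, with oxygen atoms that none of the earlier groups has, also gives a far lower number than 3,5-dimethylphenyl, and compound 3 remains the outlier among the four. The ester group does not match the two best groups, however, with a 10-fold higher number from compound 2 to compound 4 (1.02 log units; beyond the scatter) and a 36-fold higher number from compound 1 to compound 4 (1.56 log units; beyond the scatter), which shows that the groups at this position spread over a graded range rather than falling into just two levels. Nothing available explains why these groups rank as they do.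

The compounds shown leave open whether the ester itself matters, since a carboxylic acid or a primary amide in its place would test this. They also leave open how a 3,4-dichlorophenyl group would compare with the 3,4-dimethylphenyl group of compound 1.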